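The compounds below may be only part of what the source reports. "The series", "measured", "known", "first", "only" and "open" are said of these compounds alone.

Compound 1 `CCSC(=S)SCc1ccc(OC)cc1` was measured in a functional assay on HeLa cells (Homo sapiens) for antiproliferative activity, read by resazurin assay, tested at 25 uM (on this read-out lower numbers stand for less inhibition and higher numbers for more inhibition at the one concentration tested (going by the name of the read-out)), where compound 1 gives 0%. Compound 2 `CCSC(=S)SCCCC(=O)c1ccc(Cl)cc1` gives 0% in this assay, so compound 1 stands level with compound 2, the two values lying within the usual scatter of repeated measurements. Compound 3 `CCSC(=S)SC(O)c1ccc(OC)cc1` has not yet been measured. It differs from compound 1 by hydroxy in place of hydrogen on a saturated chain carbon bound to an aromatic carbon and a sulfur. With both measured compounds showing no inhibition at all, the expected step in this assay is a number 2 percentage points higher from compound 1 to compound 3 (within the scatter), meaning no change beyond the scatter. For compound 3 in this assay the estimate is 2%, with a range from 0% to 12%.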

Compound 3, a percentage reported as inhibition, at one concentration (the size of the read-out at that concentration, not a potency): 0%
Compound 3: middle estimate off by 2 percentage points, on the high side, and the stated range covers the measured number.
By their numbers in this assay, from the lowest: compounds 1, 2 and 3 (each within the scatter of the next).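

Putting hydroxy in place of hydrogen on the saturated chain carbon bound to an aromatic carbon and a sulfur gives no change at the digits printed from compound 1 to compound 3 (within the scatter) in this assay at the one concentration tested. For the compounds shown here, this is the first single-place comparison in the set, and adding this group at this position does not bring out any inhibition. Nothing available explains this result.

As far as these compounds go, with all three compounds at the bottom of the scale, it remains open whether this change would matter in a compound that does inhibit. An amine, a carboxylic acid or a longer chain on this carbon remains an open case.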